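The source may hold more compounds than are shown below. What is called first, only, known or untested is meant among the compounds shown, and "the series" means these compounds.

Working notes on the series.

Compound 1 `Cc1c(/C=N\O)cc(-c2ccc(S(C)(=O)=O)cc2)n1-c1cccc(F)c1` and compound 2 `Cc1c(/C=N\O)cc(-c2ccc(S(C)(=O)=O)cc2)n1-c1ccc(F)c(F)c1` share one core and differ only in the group on the aromatic nitrogen. In a functional assay on the whole organism (strain Swiss albino) for inhibition, with Mus musculus as the target, in the writhing test, with a stated time of 30 min, at a dose of 20 mg/kg by the oral route (a lower number here means a weaker effect, a higher number a stronger effect of the compound at the dose given), compound 1 gives 42% and compound 2 gives 27%. For the measured compounds named here, the one measured step, a number 15 percentage points lower from compound 1 to compound 2 (beyond the scatter), is the only comparison available. Going by the values given here, on these two numbers compound 2 stands lowest, with compound 1 as its only neighbour and that neighbour beyond the scatter above it.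

Compound 3 `Cc1c(/C=N\O)cc(-c2ccc(S(C)(=O)=O)cc2)n1-c1ccccc1` is not yet measured in this assay. Its change from compound 2 is phenyl in place of 3,4-difluorophenyl on an aromatic nitrogen. The step from compound 1 to compound 2 bears directly on this move, since it shows what one fluoro on that ring did; compound 3 takes that fluoro away again and a second one besides. Among the compounds with values here, for the first part the step is expected to reverse; for the second part no measured pair exists, so it is treated as neutral. The step expected is therefore a number 13 percentage points higher from compound 2 to compound 3 (beyond the scatter), upward and of modest size. Compound 3 is estimated at 40%, between 25% and 55%.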

Compound 3, a percentage reported as inhibition, in the whole organism at one dose (the size of the read-out at that dose, not a potency): 53%
The estimate for compound 3 lay 13 percentage points below the measured number; the measured number falls inside the stated range.
By their numbers in this assay, from the lowest: compound 2; then compound 1; then compound 3.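

Phenyl in place of 3,4-difluorophenyl on an aromatic nitrogen gives in this assay a number 26 percentage points higher from compound 2 to compound 3 (beyond the scatter) and hydrogen in place of the single fluoro gives a number 11 percentage points higher from compound 1 to compound 3 (beyond the scatter) so among these three compounds the unsubstituted phenyl carries the highest number, and the number falls with each fluoro present on that ring, with no compound shown going against this order. The earlier pair showed only that adding a second fluoro to a ring already bearing one lowered the number; compound 3 now shows that the first fluoro also comes with a lower number, so at this position no fluoro shown has raised the read-out. No supporting data bear on the reason for this order.

The compounds shown leave open whether the fall belongs to fluoro itself or would also appear with another group on the same ring, such as chloro, methoxy or an amine. They also leave open how a group other than an aromatic ring, such as a short alkyl chain or a cyclohexyl ring, would read on this aromatic nitrogen at the dose given.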